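Ring ethers on a shared core at a hormone receptor

This account rests on a few compounds, and the source may have more. Where it says the series, first, only, none or still open, it means among the compounds named here.

Compound 2 `Nc1ccc2cccc(OCC3CCCC3)c2n1` gives 53 nM in an assay on cells with melanin-concentrating hormone receptor 1 (Homo sapiens) as the target, read by radioligand binding (a higher number here means a weaker inhibitor, a lower number a stronger inhibitor), the lowest of the two numbers recorded. Compound 1 `CC1CCCC(Oc2cccc3ccc(N)nc23)C1` gives 640 nM in this assay, a gap beyond the usual scatter. Compound 3 `CC(CC(C)(C)C)Oc1cccc2ccc(N3CCCC3)nc12` reaches only a limit of this assay, > 2000 nM. Compound 4 `CC1CCC(Oc2cccc3ccc(N)nc23)C1` differs from compound 2 in a single place: 3-methylcyclopentyl in place of cyclopentylmethyl on an oxygen on an aromatic ring. Within the data shown here, no measured pair shows this change directly. Compound 1, whose ring is joined straight to the oxygen on the aromatic ring, gives 640 nM, so a weakening step in this assay is expected for compound 4. Compound 4 is estimated at 250 nM, within 60 nM to 1000 nM. The expected step is a 4.7-fold higher number from compound 2 to compound 4 (0.67 log units; beyond the scatter).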

Compound 4, half-maximal inhibitory concentration: 823 nM
Estimate against measurement, compound 4: 3.3-fold (0.52 log units) below; low and high end bracket the measured number.
By their numbers in this assay, from the lowest: compound 2; then compounds 1 and 4 (each within the scatter of the next). At a limit, above all of these: compound 3.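

In this assay, 3-methylcyclopentyl in place of cyclopentylmethyl on an oxygen on an aromatic ring gives a 16-fold higher number from compound 2 to compound 4 (1.19 log units; beyond the scatter), the first step read directly at this position, and the two groups hold the same atoms, joined differently. Compound 1 and compound 4, both with the ring joined straight to the oxygen, lie within the scatter of each other. Nothing shown gives a reason for this step.

On these data alone, what remains open is how a plain cyclopentyl or a cyclohexylmethyl group on the same oxygen would read, which would separate the role of the ring methyl from that of the carbon linking ring and oxygen.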